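An Octyl Chain Replaces Fluorophenyl in Compound 4

The source may hold more compounds than are shown below. What is called first, only, known or untested is meant among the compounds shown, and "the series" means these compounds.

Of the compounds shown here, three sharing one core have been measured in an ADME assay on SK-OV-3 cells (Homo sapiens) for cytotoxicity, read by sulforhodamine B assay, with a stated time of 48 h, tested at 10 uM; on this read-out lower numbers stand for less inhibition and higher numbers for more inhibition at the one concentration tested (going by the name of the read-out). Compound 1 `COc1nc2ccc(Br)cc2cc1C(c1ccccc1)n1cc(C2CC2)nn1` gives 3.52%; compound 2 `COc1nc2ccc(Br)cc2cc1C(c1ccccc1)n1cc(-c2ccccc2F)nn1` gives 7.33%; compound 3 `COc1nc2ccc(Br)cc2cc1C(c1ccccc1)n1cc(CCCCCO)nn1` gives 8.69%. All three numbers are low, and the steps among them are small: a number 3.8 percentage points higher from compound 1 to compound 2 (within the scatter), a number 5.2 percentage points higher from compound 1 to compound 3 (within the scatter), and a number 1.4 percentage points higher from compound 2 to compound 3 (within the scatter). Compound 2 thus stands within the scatter of both companions, with compound 3 closest to it and compound 1 furthest from it.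

Compound 4 `CCCCCCCCc1cn(C(c2ccccc2)c2cc3cc(Br)ccc3nc2OC)nn1` has not yet been measured. It differs from compound 2 in one place: octyl in place of 2-fluorophenyl on an aromatic carbon. Among the compounds with values here, none of the measured steps involves an octyl group, so the only guidance is that exchanging cyclopropyl for 2-fluorophenyl, exchanging cyclopropyl for 5-hydroxypentyl, and exchanging 2-fluorophenyl for 5-hydroxypentyl all left the numbers in this assay within the scatter. On that basis no step beyond the scatter is expected for the exchange of 2-fluorophenyl for octyl, and the estimated step is a number 0.7 percentage points higher from compound 2 to compound 4 (within the scatter). Compound 4 is therefore expected to give about 8% in this assay, with a range from 0% to 22%.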

Compound 4, a percentage reported as inhibition, at one concentration (the size of the read-out at that concentration, not a potency): 2.06%
Beside the measured number, compound 4's estimate is 5.9 percentage points above it; the range from low to high includes it.
By their numbers in this assay, from the lowest: compounds 4, 1, 2 and 3 (each within the scatter of the next).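

In this assay, octyl on this aromatic carbon of the five-membered aromatic ring stays within the scatter of all three earlier compounds (a number 5.3 percentage points lower from compound 2 to compound 4 (within the scatter); a number 6.6 percentage points lower from compound 3 to compound 4 (within the scatter); a number 1.5 percentage points lower from compound 1 to compound 4 (within the scatter)). The position therefore now holds a ringless group of 8 carbon atoms, and the numbers do not separate it from the 2-fluorophenyl of compound 2, the cyclopropyl of compound 1 or the 5-hydroxypentyl of compound 3, so these four compounds show no clear effect of exchanging one of these groups for another in this assay. No measurement given here explains the values of these compounds.

As far as these compounds go, whether an amine or a carboxylic acid at the end of the chain, or a chain longer than octyl, would give a step beyond the scatter remains open. Within the data shown here, each compound also has only a single reading at one concentration in this assay, so these numbers leave the potency of all four compounds undefined, and they do not show whether changes elsewhere on the shared core would have a larger effect.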